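This account rests on a few compounds, and the source may have more. Where it says the series, first, only, none or still open, it means among the compounds named here.

Compound 1 `COc1ccc(-c2cc(/C=C/C(=O)c3ccc(N)cc3)[nH]n2)cc1`, compound 2 `COc1ccc(-c2cc(/C=C/C(=O)c3ccc(N)cc3)[nH]n2)cc1OC` and compound 3 `COc1cc(C(=O)/C=C/c2cc(-c3cc(OC)c(OC)c(OC)c3)n[nH]2)cc(OC)c1OC` have been measured, while compound 4 `COc1ccc(-c2cc(/C=C/C(=O)c3cc(OC)c(OC)c(OC)c3)[nH]n2)cc1OC` has not. In a functional assay on HCT-116 cells (Homo sapiens) for inhibition, read by sulforhodamine B assay, with a stated time of 48 h (on this read-out higher numbers stand for weaker inhibition of growth and lower numbers for stronger inhibition of growth), compound 1 gives 1380 nM, compound 2 gives 1710 nM and compound 3 gives 1310 nM. The change from compound 2 to compound 1 is hydrogen in place of methoxy on an aromatic carbon, and it made a 1.2-fold lower number from compound 2 to compound 1 (0.09 log units; within the scatter). How the core of compound 3 differs from that of compound 2 is not broken down here. The change from compound 3 to compound 4 is hydrogen in place of methoxy on an aromatic carbon; it is the same kind of change, though here the place is also meta to a methoxy group. Because a 1.2-fold lower number from compound 2 to compound 1 (0.09 log units; within the scatter) lay within the scatter, the step from compound 3 to compound 4 is expected to be small, a 1.1-fold lower number from compound 3 to compound 4 (0.04 log units; within the scatter). Compound 4 is therefore estimated at 1200 nM, expected between 600 nM and 2500 nM in this assay.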

Compound 4, concentration for 50% growth inhibition: 420 nM
Estimate against measurement, compound 4: 2.9-fold (0.46 log units) above; measured number outside the range, below it.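

In this assay, hydrogen in place of methoxy gave a 3.1-fold lower number from compound 3 to compound 4 (0.49 log units; beyond the scatter), a larger step than the one seen on the other core, but the two cannot be told apart: the same change on two cores in this assay, a 1.2-fold lower number (0.09 log units; within the scatter) from compound 2 to compound 1 and a 3.1-fold lower number (0.49 log units; beyond the scatter) from compound 3 to compound 4, 2.5-fold (0.40 log units) apart, within the scatter of two such steps The change can therefore be carried between these two cores without a measurable difference in its effect. This does not show that the step is the same on both, nor that the core alters it, and two pairs cannot establish a rule for the series.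

The compounds shown leave open how a hydroxyl group, a fluorine atom or a longer chain such as ethoxy would compare with methoxy and hydrogen at this place. They also leave open how the change behaves on a third core.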